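Removing one methoxy from compound 3

A few compounds are considered here, and "the series" means these few. Any claim that something is new, unique, unknown or untested is made for them only; others in the source may bear on it.

Values in a functional assay on MCF7 cells (Homo sapiens) for cytotoxicity, read by MTT assay, with a stated time of 24 h; on this read-out higher numbers stand for weaker inhibition of growth and lower numbers for stronger inhibition of growth:
- compound 1: `COc1ccc(/C=C/C(=O)c2ccc(OCC=C(C)C)cc2O)c(OC)c1OC`, > 100000 nM (a limit)
- compound 2: `COc1ccc(/C=C/C(=O)c2ccc(OCC=C(C)C)cc2O)cc1OC`, > 100000 nM (a limit)
- compound 3: `COc1ccc(/C=C/C(=O)c2ccc(OCC=C(C)C)cc2OCC=C(C)C)c(OC)c1OC`, 92000 nM
- compound 4: `COc1ccc(/C=C/C(=O)c2ccc(OCC=C(C)C)cc2OCC=C(C)C)cc1OC`, not yet measured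

Among the compounds with values here, compound 3 gives the only true number, 92000 nM. The other two values stand at the limit of > 100000 nM in this assay, at which 2 of the 3 values shown sit.

The next step puts hydrogen in place of methoxy on an aromatic carbon of compound 3 to give compound 4: hydrogen in place of methoxy on an aromatic carbon. The same replacement has been measured once, as a step that the two limits leave unreadable from compound 1 to compound 2, so it offers no size to carry over. The other measured step, an at least 1.0-fold lower number from compound 1 to compound 3 (0.03 log units; that floor lies within the scatter), is a different change: 3-methylbut-2-en-1-yl in place of hydrogen on an oxygen on an aromatic ring. Neither step points to a direction, so no shift beyond the scatter is expected in this assay, and a limit remains a possible result. The expected step is a 1.0-fold higher number from compound 3 to compound 4 (0.01 log units; within the scatter). For compound 4 the estimated value is 95000 nM, with an expected range from 45000 nM to 200000 nM.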

Compound 4, concentration for 50% growth inhibition: 66500 nM
Beside the measured number, compound 4's estimate is 1.4-fold (0.15 log units) above it, within the range that was stated.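

In this assay, hydrogen in place of methoxy on this aromatic carbon now has a readable size, a 1.4-fold lower number from compound 3 to compound 4 (0.14 log units; within the scatter), so with the 3-methylbut-2-en-1-yl group on the oxygen this replacement does not move the value beyond the scatter; on the earlier pair, the same replacement could not be read. The 3-methylbut-2-en-1-yl change now stands on a second core, as an at least 1.5-fold lower number from compound 2 to compound 4 (0.17 log units; that floor lies within the scatter), and its size is still bounded on one side only: the same change on two cores in this assay, an at least 1.0-fold lower number (0.03 log units; that floor lies within the scatter) from compound 1 to compound 3 and an at least 1.5-fold lower number (0.17 log units; that floor lies within the scatter) from compound 2 to compound 4; the limit leaves it open whether they differ. Compound 1 and compound 2 remain limits, so neither gives a number for that change: the limit of > 100000 nM in this assay, at which 2 of the 4 values shown sit.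

Going by these compounds, how far the 3-methylbut-2-en-1-yl change moves the value on either core stays open. Also open, on these data alone, is whether an amine or a carboxylic acid on this aromatic carbon would give a shift beyond the scatter.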